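Moving the fluorine on compound 1

The source may hold more compounds than are shown below. What is called first, only, known or untested is meant among the compounds shown, and "the series" means these compounds.

Compound 1 `COC(=O)/C(=C/c1ccccc1)CN1C(=O)[C@@H](OC)[C@H]1c1ccc(F)cc1`: 27900 nM
Compound 2 `COc1ccc(OC)c([C@@H]2[C@H](OC)C(=O)N2C/C(C#N)=C/c2ccccc2)c1`: > 100000 nM (a limit of the assay)

For the measured compounds named here, in an ADME assay on cells (Epithelial cell, Homo sapiens) for antiproliferative activity, read by MTT assay, with a stated time of 48 h (a higher number here means a weaker inhibitor, a lower number a stronger inhibitor), compound 1 gives 27900 nM, the only true number so far. Compound 2 reads > 100000 nM, which is a limit and not a number. Compound 3 `COC(=O)/C(=C/c1ccccc1)CN1C(=O)[C@@H](OC)[C@H]1c1cccc(F)c1` has the same atoms as compound 1, joined differently, with 3-fluorophenyl in place of 4-fluorophenyl on a saturated ring carbon. Going by the values given here, no measured pair shows the effect of this change. Expected in this assay is a 1.0-fold higher number from compound 1 to compound 3 (0.00 log units; within the scatter), within the scatter, with no direction favoured. The estimate for compound 3 is 28000 nM, with an expected range from 12000 nM to 70000 nM.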

Compound 3, half-maximal inhibitory concentration: 38500 nM
Beside the measured number, compound 3's estimate is 1.4-fold (0.14 log units) below it; low and high end bracket the measured number.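

In this assay, the move of the fluorine is a 1.4-fold higher number from compound 1 to compound 3 (0.14 log units; within the scatter). For the compounds shown here, this is the first measured change at this position, and at this reading 3-fluorophenyl and 4-fluorophenyl on the saturated ring carbon are not told apart. Nothing shown bears on a cause for this step.

Still open, from the compounds shown here alone, is whether this position tolerates a different kind of group, such as an amine or a carboxylic acid on the phenyl ring in place of the fluorine. Also open, going by these compounds, is how a longer chain between the ring carbon and the phenyl ring would read.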